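Oxadiazole series: a dimethoxypyrimidine replaces the phenyl

A few compounds are considered here, and "the series" means these few. Any claim that something is new, unique, unknown or untested is made for them only; others in the source may bear on it.

Measured compounds:
compound 1, `C[C@H](c1ccccc1)N1C(=O)O[C@](Cc2ccccc2)(c2nnc(-c3ccccc3)[nH]2)C1=O`, 29%
compound 2, `C[C@H](c1ccccc1)N1C(=O)O[C@](Cc2ccccc2)(c2nnc(-c3ccccc3)o2)C1=O`, 0%

In an ADME assay (liver) for metabolic stability, with Liver microsome (Rattus norvegicus) as the target, using microsomes, with a stated time of 0.5 h, tested at 1 uM (a higher number here means that more of the compound is left, a lower number that less of the compound is left), compound 2 gives 0%, the lowest of the two numbers; its nearest neighbour is compound 1, and the step of a number 29 percentage points lower from compound 1 to compound 2 (beyond the scatter) lies between them. Compound 3 `COc1cc(OC)nc(-c2nnc([C@@]3(Cc4ccccc4)OC(=O)N([C@H](C)c4ccccc4)C3=O)o2)n1` differs from compound 2 in one place: 4,6-dimethoxypyrimidin-2-yl in place of phenyl on an aromatic carbon. Among the measured compounds shown here, no measured step bears on this change; the only known step concerns the five-membered ring, not the group on it. With compound 2 leaving none of the compound, the step is expected to be a number 8 percentage points higher from compound 2 to compound 3 (within the scatter), upward or none beyond the scatter. Compound 3 is estimated at 8%, between 0% and 30%.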

Compound 3, percent of the compound remaining: 0%
Beside the measured number, compound 3's estimate is 8 percentage points above it, within the range that was stated.
By their numbers in this assay, from the lowest: compounds 2 and 3 (each within the scatter of the next); then compound 1.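

With 4,6-dimethoxypyrimidin-2-yl in place of phenyl, this assay shows no change at the digits printed from compound 2 to compound 3 (within the scatter) on this aromatic carbon. Compound 3 stands at 0% on a read-out that can go no lower, so a further loss could not appear here, and this replacement brings no recovery. Nothing at hand explains the result. On these data alone, whether the same replacement would move compound 1, at 29%, stays open. So does whether an amine or a carboxylic acid on this aromatic carbon would leave any compound remaining.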